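This account rests on a few compounds, and the source may have more. Where it says the series, first, only, none or still open, it means among the compounds named here.

In a functional assay on blood for antagonist activity at thromboxane A2 receptor (Homo sapiens) (on this read-out lower numbers stand for tighter binding and higher numbers for weaker binding), three compounds have been measured. Compound 1 `O=C(O)CC/C=C\CO[C@@H]1[C@@H](OCc2ccc(-c3ccccc3)cc2)CC[C@@H]1N1CCCCC1` gives 100 nM, compound 3 `O=C(O)CC/C=C\CO[C@H]1[C@@H](OCc2ccc(-c3ccccc3)cc2)CC[C@@H]1N1CCCCCC1` gives 5.01 nM, and compound 2 `O=C(O)CC/C=C\CO[C@H]1C(OCc2ccc(-c3ccccc3CCO)cc2)CC[C@@H]1N1CCCCCC1` gives 2 nM, the lowest of the three numbers, with compound 3 nearest and compound 1 furthest, both beyond the scatter. Compound 4 `O=C(O)CC/C=C\CO[C@H]1C(OCc2ccc(-c3ccccc3CO)cc2)CC[C@@H]1N1CCCCCC1` differs from compound 2 by hydroxy in place of hydroxymethyl on a saturated chain carbon bound to an aromatic carbon. Going by the values given here, no step between measured compounds shows this change, so the expectation for compound 4 rests on compound 2 alone. The expected step is a 1.5-fold higher number from compound 2 to compound 4 (0.18 log units; within the scatter), which is thought to stay within the scatter in either direction. Compound 4 is therefore estimated to give 3 nM in this assay, with a range from 1 nM to 9 nM.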

Compound 4, dissociation constant: 3.16 nM
Compound 4: middle estimate off by 1.1-fold (0.02 log units), on the low side; the measured number falls inside the stated range.
By their numbers in this assay, from the lowest: compounds 2, 4 and 3 (each within the scatter of the next, the first and the last beyond it); then compound 1.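

In this assay, cutting 2-hydroxyethyl back to hydroxymethyl gives a 1.6-fold higher number from compound 2 to compound 4 (0.20 log units; within the scatter) and so shows that this position tolerates the change within the scatter. Going by these compounds alone, this is the first direct reading at this position, since no earlier pair differed here in one place alone. Nothing available explains this result. Going by these compounds, whether an amine, a carboxylic acid or a longer chain such as 3-hydroxypropyl would read the same in this place stays open, as does whether the step holds on other cores.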